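The source may report more compounds than this note shows. Statements on the series, on what has been measured and on what is new or still open speak of the compounds shown alone.

In a functional assay on the whole organism (Abdomen) with Mus musculus as the target (on this read-out higher numbers stand for an effect only at larger amounts of compound and lower numbers for an effect already at smaller amounts), compound 3 (`CCc1nc(Cc2c[nH]cn2)c(C)s1`) stands at > 30 mg/kg and this is a limit, not a number. Compound 1 (`CCc1nc(Cc2c[nH]cn2)c(CC)s1`) gives 1.8 mg/kg in this assay and compound 2 (`CC(C)c1nc(Cc2c[nH]cn2)c(C(C)C)s1`) gives 23.8 mg/kg there, so these two carry measured numbers. Compound 4 (`CCc1nc(Cc2c[nH]cn2)c(C(C)C)s1`) follows from compound 3 through isopropyl in place of methyl on an aromatic carbon, next to the ring sulfur (isopropyl in place of methyl on an aromatic carbon). Among the measured compounds shown here, one measured step bears on that place (an at least 16-fold higher number from compound 1 to compound 3 (1.22 log units; beyond the scatter)) and it is large and beyond the scatter. That step ends at the same methyl that leaves here, so a large move to a lower number is expected in this assay once isopropyl enters. For the measured compounds named here, the expected step (an at least 5.0-fold lower number from compound 3 to compound 4 (0.69 log units; beyond the scatter)) stays rough, as its starting point is only a limit and no measured step has isopropyl entering alone. The estimate for compound 4 is (6 mg/kg) with an expected range (1.5 mg/kg to 25 mg/kg) on this read-out.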

Compound 4, dose for half-maximal effect: 25.3 mg/kg
Beside the measured number, compound 4's estimate is 4.2-fold (0.62 log units) below it; the whole stated range lies below it.
By their numbers in this assay, from the lowest: compound 1; then compounds 2 and 4 (each within the scatter of the next). At a limit, above all of these: compound 3.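

In this assay, one added methyl on the ethyl group next to the ring sulfur is enough for a large move: a 14-fold higher number from compound 1 to compound 4 (1.15 log units; beyond the scatter). With isopropyl at this place, the other chain counts for little: a 1.1-fold higher number from compound 2 to compound 4 (0.03 log units; within the scatter). The same listed change differs in size between two cores: the same change on two cores in this assay, an at least 16-fold higher number (1.22 log units; beyond the scatter) from compound 1 to compound 3 and a 1.1-fold higher number (0.03 log units; within the scatter) from compound 2 to compound 4, at least 15-fold (1.19 log units) apart, beyond the scatter of two such steps. Compound 3 stands at > 30 mg/kg, which is a limit. The step that starts from this limit gives only a floor: an at least 1.1-fold lower number from compound 3 to compound 4 (0.07 log units; that floor lies within the scatter).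

The compounds shown leave open how a longer chain, such as propyl, or a cyclopropyl group would behave next to the ring sulfur. They also leave open whether an amine or a carboxylic acid at this place would fit the same trend, since only methyl, ethyl and isopropyl appear there.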